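Bulkier Silyl Ether at the Primary Oxygen: Expected Tolerance

The compounds below may be only part of what the source reports. "The series", "measured", "known", "first", "only" and "open" are said of these compounds alone.

Measured compounds in an ADME assay on HEL cells (Homo sapiens) for cytotoxicity, with a stated time of 3 days; a lower number here means that less compound is tolerated, a higher number that more compound is tolerated:
Compound 1 `Cc1cn([C@@H]2O[C@H](CO[Si](C)(C)C(C)(C)C)[C@@]3(OS(=O)(=O)C=C3NC(=O)NC(=O)c3ccccc3)[C@H]2O[Si](C)(C)C(C)(C)C)c(=O)n(C)c1=O` gives >= 80000 nM, which is a limit of the assay rather than a number.
Compound 2 `Cc1cn([C@@H]2O[C@H](CO)[C@@]3(OS(=O)(=O)C=C3NC(=O)NC(=O)c3ccccc3)[C@H]2O[Si](C)(C)C(C)(C)C)c(=O)n(C)c1=O` gives 20000 nM.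

Going by the values given here, compound 2 is therefore the only compound with a definite number in this assay; the other value shown is a limit. Among the compounds with values here, the single measured step runs the other way from the one of interest here: an at least 4.0-fold lower number from compound 1 to compound 2 (0.60 log units; beyond the scatter). That step rests on a limit, (the limit of >= 80000 nM in this assay, at which 1 of the 2 values shown sits), so its true size is only known as a minimum.

Compound 3 `Cc1cn([C@@H]2O[C@H](CO[Si](C)(C)C(C)(C)C(C)C)[C@@]3(OS(=O)(=O)C=C3NC(=O)NC(=O)c3ccccc3)[C@H]2O[Si](C)(C)C(C)(C)C)c(=O)n(C)c1=O` differs from compound 2 in one place: a group of 9 heavy atoms (8 carbon, 1 silicon; no ring) in place of a hydrogen atom, on an oxygen on a saturated carbon. Within the data shown here, this reverses the measured step, and the group that enters is larger than the one that left between compound 1 and compound 2. The number for compound 3 is therefore expected to rise, with a step of about a 4.0-fold higher number from compound 2 to compound 3 (0.60 log units; beyond the scatter), quite possibly back to a limit. The estimate for compound 3 is 80000 nM, within a range of 40000 nM to 160000 nM.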

Compound 3, minimum cytotoxic concentration: >= 100000 nM
Compound 3 was reported as a limit; the forecaster's own chance of this, stated with the estimate: 60%; at least 1.2-fold (0.09 log units) between middle value and limit.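

Compound 3 adds a second case to compound 1: with a silyl group on this oxygen, the value in this assay sits at a limit, while compound 2, with a hydrogen there, is the only one of the three with a definite number. Restoring a silyl group, this time the one of 9 heavy atoms, gives an at least 5.0-fold higher number from compound 2 to compound 3 (0.69 log units; beyond the scatter), so the lower number of compound 2 goes with the hydrogen at this oxygen in both steps that can be read. For compound 3, >= 100000 nM is a limit and not a number, and the step between compound 1 and compound 3, isopropyl in place of methyl, cannot be read, as both values are limits: the limit of >= 100000 nM in this assay, at which 1 of the 3 values shown sits.

As far as these compounds go, how much compound is actually tolerated with either silyl group therefore stays unknown, and no difference between the two groups can be claimed. From the compounds shown here alone, compound 2 gives 20000 nM, and it remains open whether an acetyl or a benzyl group on this oxygen would raise that number as the silyl groups do, or whether the rise belongs to silyl groups alone.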